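Adding a Third Methoxy Group on the Ketone Side

The compounds below may be only part of what the source reports. "The series", "measured", "known", "first", "only" and "open" are said of these compounds alone.

Measured compounds:
Compound 1, `COc1cc(-c2cc(/C=C/C(=O)c3ccc(N)cc3)[nH]n2)cc(OC)c1OC`: 3200 nM
Compound 2, `COc1ccc(C(=O)/C=C/c2cc(-c3cc(OC)c(OC)c(OC)c3)n[nH]2)cc1OC`: 1800 nM

Both compounds share a core and differ only in the ring attached to the carbonyl carbon. In a functional assay on IGROV-1 cells (Homo sapiens) for inhibition, read by sulforhodamine B assay, with a stated time of 48 h (on this read-out higher numbers stand for weaker inhibition of growth and lower numbers for stronger inhibition of growth), compound 1 gives 3200 nM, and compound 2 gives 1800 nM. Among the measured compounds shown here, the one measured step, a 1.8-fold lower number from compound 1 to compound 2 (0.25 log units; within the scatter), swapped a 4-aminophenyl for a 3,4-dimethoxyphenyl and changed the number only within the scatter. Compound 2 therefore holds the lower of the two numbers, but the gap to compound 1 is too small to call it the stronger inhibitor of growth.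

Compound 3, `COc1cc(C(=O)/C=C/c2cc(-c3cc(OC)c(OC)c(OC)c3)n[nH]2)cc(OC)c1OC`, differs from compound 2 by methoxy in place of hydrogen on an aromatic carbon. For the measured compounds named here, no measured step tests such an addition: the only step available exchanged a whole ring substituent and stayed within the scatter. With so little to go on, the expectation for compound 3 is a step of a 1.3-fold lower number from compound 2 to compound 3 (0.11 log units; within the scatter) that stays within the scatter, with no clear direction. The estimate for compound 3 in this assay is 1400 nM, with a range from 450 nM to 4500 nM.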

Compound 3, concentration for 50% growth inhibition: 3140 nM
For compound 3 the middle estimate is 2.2-fold (0.35 log units) below the measured one; the measured number falls inside the stated range.
By their numbers in this assay, from the lowest: compounds 2, 3 and 1 (each within the scatter of the next).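

This position on the ring attached to the carbonyl carbon is an aromatic carbon ortho to a methoxy group, and compound 3 gives the first direct test of a methoxy in place of hydrogen there. In this assay the addition gives a 1.7-fold higher number from compound 2 to compound 3 (0.24 log units; within the scatter) and so leaves compound 2 and compound 3 indistinguishable, which means this small, uncharged group with one hydrogen-bond acceptor can be placed on this carbon without a change that can be read from these numbers. Nothing measured here offers an explanation for this result, and a flat step from one pair of compounds is not a rule for the position.

The compounds shown leave open whether a different group on this same aromatic carbon, such as an amine, a hydroxyl group or a longer chain like ethoxy, would move the number beyond the scatter. They also leave open whether any change elsewhere on the shared core would shift growth inhibition more clearly than the changes on this ring have so far.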